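A few compounds are considered here, and "the series" means these few. Any claim that something is new, unique, unknown or untested is made for them only; others in the source may bear on it.

Working notes on the aryl hydrazone series. Compound 3 `CN(C)CCn1cnnc1-c1cc(Oc2ccc(NC(=O)N/N=C/c3ccc(O)c(F)c3)cc2F)ccn1` gives 1970 nM in a functional assay on MKN-45 cells (Homo sapiens) for cytotoxicity, read by MTT assay, with a stated time of 72 h (a lower number here means a stronger inhibitor, a higher number a weaker inhibitor), the second highest of the three numbers; compound 1 `CN(C)CCn1cnnc1-c1cc(Oc2ccc(NC(=O)N/N=C/c3ccc(F)cc3)cc2F)ccn1` gives 1030 nM and compound 2 `COc1cc(/C=N/NC(=O)Nc2ccc(Oc3ccnc(-c4nncn4CCN(C)C)c3)c(F)c2)cc(OC)c1OC` gives 2900 nM, and both steps, a 1.9-fold higher number from compound 1 to compound 3 (0.28 log units; within the scatter) and a 1.5-fold lower number from compound 2 to compound 3 (0.17 log units; within the scatter), stay within the scatter. Compound 4 `CN(C)CCn1cnnc1-c1cc(Oc2ccc(NC(=O)N/N=C/c3cccc(O)c3)cc2F)ccn1` carries the change (3-hydroxyphenyl in place of 3-fluoro-4-hydroxyphenyl on a carbon with a double bond to nitrogen). The aryl swaps seen so far at this carbon, a 2.8-fold higher number from compound 1 to compound 2 (0.45 log units; beyond the scatter) included, span only a modest range, so no step beyond the scatter is expected in this assay. Compound 4 is therefore expected to give about 1800 nM, with a range of 800 nM to 4500 nM. The step from compound 3 is expected to be a 1.1-fold lower number from compound 3 to compound 4 (0.04 log units; within the scatter).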

Compound 4, half-maximal inhibitory concentration: 1370 nM
Compound 4: middle estimate off by 1.3-fold (0.12 log units), on the high side; the measured number falls inside the stated range.
By their numbers in this assay, from the lowest: compounds 1, 4, 3 and 2 (each within the scatter of the next, the first and the last beyond it).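

In this assay, 3-hydroxyphenyl does not separate from 3-fluoro-4-hydroxyphenyl (a 1.4-fold lower number from compound 3 to compound 4 (0.16 log units; within the scatter)) or from 4-fluorophenyl (a 1.3-fold higher number from compound 1 to compound 4 (0.12 log units; within the scatter)). It does separate from 3,4,5-trimethoxyphenyl (a 2.1-fold lower number from compound 2 to compound 4 (0.33 log units; beyond the scatter)), so compound 2 now lies beyond the scatter of two compounds, though still within that of compound 3. No supporting measurement bears on these steps, so no cause can be assigned.

Going by these compounds, it remains open whether an amine or a carboxylic acid on the phenyl ring would move the number beyond the modest range seen so far. A longer chain between this carbon and the ring is equally untested by the compounds shown.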